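Trimming one methoxy group from compound 1

The source may hold more compounds than are shown below. What is called first, only, known or untested is meant among the compounds shown, and "the series" means these compounds.

In a functional assay on HCT-116 cells (Homo sapiens) for inhibition, read by sulforhodamine B assay, with a stated time of 48 h, tested at 50 uM (a higher number here means more inhibition of growth at the concentration tested, a lower number less inhibition of growth), compound 1 (`COc1ccc(/C=C/C(=O)/C=C/c2ccc(OCc3cn(CCCCCOc4cc(=O)oc5ccccc45)nn3)c(OC)c2)cc1OC`) gives 45% of growth inhibition. Compound 3 (`COc1ccccc1/C=C/C(=O)/C=C/c1ccc(OCc2cn(CCCOc3cc(=O)oc4ccccc34)nn2)c(OC)c1`) gives 53% in the same test, within the usual scatter of compound 1, so the two cannot be ranked. Compound 2 (`COc1cc(/C=C/C(=O)/C=C/c2cccs2)ccc1OCc1cn(CCOc2cc(=O)oc3ccccc23)nn1`) gives 71% and stands clearly above both. These three differ in several places at once, so no single structural change has yet been measured on its own.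

Compound 4 (`COc1ccc(/C=C/C(=O)/C=C/c2ccc(OCc3cn(CCCCCOc4cc(=O)oc5ccccc45)nn3)c(OC)c2)cc1`) is compound 1 with one alteration (hydrogen in place of methoxy on an aromatic carbon): hydrogen in place of methoxy on an aromatic carbon, which turns 3,4-dimethoxyphenyl into 4-methoxyphenyl. With no direct comparison available, no step beyond the scatter is expected in this assay in either direction. Compound 3 also carries a single methoxy on that end ring and gives 53% of inhibition, which offers no sign of a large move, although its chain differs too. The expected step of a number 3 percentage points higher from compound 1 to compound 4 (within the scatter) is therefore small. Compound 4 is expected at 48% with an estimated range of 33% to 63% in this test.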

Compound 4, percent growth inhibition at one concentration: 35%
Compound 4: the middle estimate sits 13 percentage points above what was measured; the range from low to high includes it.
By their numbers in this assay, from the lowest: compounds 4, 1 and 3 (each within the scatter of the next, the first and the last beyond it); then compound 2.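

In this assay, among the compounds shown here, hydrogen in place of methoxy on an aromatic carbon gives a number 10 percentage points lower from compound 1 to compound 4 (within the scatter) and this is the first change seen on its own. Turning 3,4-dimethoxyphenyl into 4-methoxyphenyl on this chain therefore leaves compound 1 and compound 4 unranked, and nothing here shows that this methoxy group is needed for growth inhibition at the concentration tested. No measurement at hand speaks to what lies behind this result.

On these data alone, what other groups would do at this place stays open, for instance a hydroxy group, a fluorine atom or an amine. Also open, as far as these compounds go, is whether the same trim gives a similar result when the chain is shorter or the other end of the molecule differs.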